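The source may report more compounds than this note shows. Statements on the series, on what has been measured and on what is new or still open speak of the compounds shown alone.

Compound 1 `CC(C)=CCC[C@]1(C)/C=C/[C@@H](OC(=O)C=C(C)C)[C@](C)(O)/C=C/C(=O)/C(C(=O)O)=C\C1`: in a functional assay on HL-60 cells (Homo sapiens) for antiproliferative activity, read by MTT assay, with a stated time of 48 h (a higher number here means a weaker inhibitor, a lower number a stronger inhibitor), compound 1 reaches only the assay limit > 10000 nM, not a number.
Compound 2 `CC(C)=CCC[C@]1(C)/C=C/[C@@H](OC(=O)C=C(C)C)[C@](C)(O)/C=C/C(=O)/C(CN2CCN(C)CC2)=C\C1`: in this assay compound 2 gives 840 nM.

Compound 2 therefore holds the only real number shown; the other value is a limit. Compound 3 `CC(C)=CCC[C@]1(C)/C=C/[C@@H](OC(=O)C=C(C)C)[C@](C)(O)/C=C/C(=O)/C(CN=[N+]=[N-])=C\C1` differs from compound 2 by azido in place of 4-methylpiperazin-1-yl on a saturated chain carbon bound to a double-bonded ring carbon. Going by the values given here, the single measured step, an at least 11-fold lower number from compound 1 to compound 2 (1.07 log units; beyond the scatter), exchanges a different group and does not compare the azido with the piperazine, so it gives no direct guide. Compound 3 is expected to move a 3.6-fold higher number from compound 2 to compound 3 (0.55 log units; beyond the scatter), toward a weaker inhibitor. The estimate for compound 3 is 3000 nM, within 800 nM to 10000 nM.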

Compound 3, half-maximal inhibitory concentration: 910 nM
Compound 3: middle estimate off by 3.3-fold (0.52 log units), on the high side; the measured number falls inside the stated range.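

In this assay, azido in place of 4-methylpiperazin-1-yl gives a 1.1-fold higher number from compound 2 to compound 3 (0.03 log units; within the scatter), so at this place two very different groups read alike, and the piperazine ring is not required for this level of activity. Azidomethyl in place of carboxy gives an at least 10-fold lower number from compound 1 to compound 3 (1.04 log units; beyond the scatter), so a second group, with no ring, also parts from the carboxy compound. Compound 1 has a limit, not a number, so neither step from it has an exact size: the limit of > 10000 nM in this assay, at which 1 of the 3 values shown sits.

Going by these compounds, whether a primary amine, a hydroxymethyl group or a longer chain at this place would read the same remains open. On these data alone, what separates the carboxy group from the other two groups also remains open.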